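The compounds below may be only part of what the source reports. "The series", "measured", "known", "first", "only" and "open" are said of these compounds alone.

Measured compounds:
- compound 1 `Cc1ccc(-c2csc(N3N=C(c4ccc(C)s4)CC3c3ccc(F)cc3)n2)cc1`: in a functional assay on A549 cells (Homo sapiens) for antiproliferative activity, read by XTT assay, with a stated time of 24 h (a lower number here means a stronger inhibitor, a higher number a weaker inhibitor), compound 1 gives > 500 ug/mL, which is a limit of the assay.
- compound 2 `Cc1ccc(C2=NN(c3nc(-c4ccc(Br)cc4)cs3)C(c3ccc(F)cc3)C2)s1`: in this assay compound 2 gives > 500 ug/mL, which is a limit of the assay.

Among the compounds with values here, compound 2 therefore stands at a limit, not at a number; both values so far sit at the limit of > 500 ug/mL in this assay, at which 2 of the 2 values shown sit. The step that the two limits leave unreadable from compound 1 to compound 2 is consequently unreadable in size. Compound 3 `COc1ccc(-c2csc(N3N=C(c4ccc(C)s4)CC3c3ccc(F)cc3)n2)cc1` differs from compound 2 by methoxy in place of bromo on an aromatic carbon. Within the data shown here, the only measured step that bears on this change is the bromo-for-methyl exchange at the same position, and its size could not be read. On that basis no step beyond the scatter can be expected in this assay, in either direction. Compound 3 is estimated at 500 ug/mL, with a range from 200 ug/mL to 1200 ug/mL. The expected step of a number no higher from compound 2 to compound 3 (the limit leaves the size open) is set at none, with a high chance that compound 3 again returns only a limit.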

Compound 3, half-maximal inhibitory concentration: 184 ug/mL
For compound 3 the middle estimate is 2.7-fold (0.43 log units) above the measured one; the measured number lies below the stated range.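

In this assay, within the data shown here, the 4-methoxyphenyl group gives the first number at this position, on an aromatic carbon para to a large group: methoxy in place of bromo gives an at least 2.7-fold lower number from compound 2 to compound 3 (0.43 log units; beyond the scatter), and methoxy in place of methyl gives an at least 2.7-fold lower number from compound 1 to compound 3 (0.43 log units; beyond the scatter). The position is therefore not silent in this assay, and among the three groups shown, only methoxy goes with a measured number rather than a limit. The step between compound 1 and compound 2 cannot be read, and the two new steps fix only a lower bound on size, because the values of compound 1 and compound 2 are limits: the limit of > 500 ug/mL in this assay, at which 2 of the 3 values shown sit.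

The compounds shown do not separate the role of the oxygen from that of the added carbon. A hydroxy group, an ethoxy group or an amine at the same place would begin to test this.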